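Removing the Methoxy Group From an Inactive Series

The source may report more compounds than this note shows. Statements on the series, on what has been measured and on what is new or still open speak of the compounds shown alone.

Compound 1 `COc1cccc(N2C(=O)COc3ccc(-c4cnc(Cl)c(NS(=O)(=O)c5ccc(F)cc5)c4)cc32)c1`: in a functional assay on MCF7 cells (Homo sapiens) for antiproliferative activity, read by MTT assay, with a stated time of 72 h (on this read-out lower numbers stand for stronger inhibition and higher numbers for weaker inhibition), compound 1 gives > 40000 nM, a limit of the assay.
Compound 2 `O=C1COc2ccc(-c3cnc(Cl)c(NS(=O)(=O)c4ccc(F)cc4)c3)cc2N1C1CCCCC1`: compound 2 gives > 40000 nM, a limit of the assay.
Compound 3 `COc1cccc(N2C(=O)COc3ccc(-c4cnc(OC)c(NS(=O)(=O)c5ccc(F)cc5)c4)cc32)c1`: compound 3 gives > 40000 nM, a limit of the assay.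

Compound 3 thus stands at the limit of the assay, and no number is known for it; the same holds for the other two compounds, as the limit of > 40000 nM in this assay, at which 3 of the 3 values shown sit, shows. The two measured steps give no size: the step that the two limits leave unreadable from compound 1 to compound 2 is unreadable, and the step that the two limits leave unreadable from compound 1 to compound 3 is unreadable as well.

Compound 4 `COc1ncc(-c2ccc3c(c2)N(c2ccccc2)C(=O)CO3)cc1NS(=O)(=O)c1ccc(F)cc1` differs from compound 3 by hydrogen in place of methoxy on an aromatic carbon. For the measured compounds named here, neither measured step bears directly on this change, and both are unreadable in any case, so no step of a readable size is available. Since all three measured compounds sit at the limit, compound 4 is expected to sit there too, so the step of a number no higher from compound 3 to compound 4 (the limit leaves the size open) is expected to be nothing that can be read. For compound 4 the estimate is 40000 nM, within a range from 15000 nM to 100000 nM, with a limit being the most likely outcome.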

Compound 4, half-maximal inhibitory concentration: 8870 nM
The estimate for compound 4 lay 4.5-fold (0.65 log units) above the measured number, and the stated range ends above it.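

For the compounds shown here, the change from 3-methoxyphenyl to phenyl gives an at least 4.5-fold lower number from compound 3 to compound 4 (0.65 log units; beyond the scatter) and is the first change in this set with a readable direction, as the earlier steps cannot be read. It shows that this position, on an aromatic carbon meta to a large group, can move a compound off the limit in this assay, and that the methoxy group is not required there for a measurable number. The step has only a lower bound, and compound 4 alone has a number: the limit of > 40000 nM in this assay, at which 3 of the 4 values shown sit.

Still open, from the compounds shown here alone, is how an amine or a carboxylic acid in place of that hydrogen would read in this assay. Also open, going by these compounds, is whether compound 4 would keep a measurable number with chloro in place of its remaining methoxy group, or with cyclohexyl in place of its phenyl.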